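The source may hold more compounds than are shown below. What is called first, only, known or untested is meant among the compounds shown, and "the series" means these compounds.

Measured so far, in a functional assay on HT-29 cells (Homo sapiens) for cytotoxicity, read by MTT assay, with a stated time of 24 h; on this read-out higher numbers stand for weaker inhibition and lower numbers for stronger inhibition:

compound 1, `Cn1c(-c2ccc(NC(=O)CSc3nc4ccccc4s3)cc2)nc(-c2ccccc2)c1-c1ccccc1`, gives 18 ug/mL
compound 2, `Cc1nnc(SCC(=O)Nc2ccc(-c3nc(-c4ccccc4)c(-c4ccccc4)n3C)cc2)s1`, gives 2.7 ug/mL
compound 3, `CN(C)/C=C/N1CCN(CC(=O)Nc2ccc(-c3nc(-c4ccccc4)c(-c4ccccc4)n3C)cc2)CC1`, gives 80 ug/mL

Compound 3 stands at the highest number of the three. The steps that reach it are a 4.4-fold higher number from compound 1 to compound 3 (0.65 log units; beyond the scatter) and a 30-fold higher number from compound 2 to compound 3 (1.47 log units; beyond the scatter), both beyond the scatter, so the shared core carries a weaker inhibitor once the piperazine replaces the sulfur-linked heteroaryl groups. The remaining step, a 6.7-fold lower number from compound 1 to compound 2 (0.82 log units; beyond the scatter), swaps one of those heteroaryl groups for another.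

Compound 4, `Cn1c(-c2ccc(NC(=O)CN3CCN(c4ccccc4)CC3)cc2)nc(-c2ccccc2)c1-c1ccccc1`, keeps the piperazine of compound 3 and changes only the group on its far ring nitrogen: phenyl in place of 2-(dimethylamino)ethenyl on an amine nitrogen in a ring. Within the data shown here, no measured step touches that position, so the three steps above bear on it only indirectly: they show that this part of the molecule moves the number by a modest to large amount when it changes, but not in which direction a phenyl would move it. The expectation is therefore a step of uncertain sign, a 1.8-fold lower number from compound 3 to compound 4 (0.25 log units; within the scatter), with a wide range around it. For compound 4 the estimate in this assay is 45 ug/mL, between 10 ug/mL and 150 ug/mL.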

Compound 4, half-maximal inhibitory concentration: 8.6 ug/mL
Compound 4: the middle estimate sits 5.2-fold (0.72 log units) above what was measured, outside the stated range (below it).
By their numbers in this assay, from the lowest: compound 2; then compound 4; then compound 1; then compound 3.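

In this assay, among these compounds, the far ring nitrogen of the piperazine now has a measured direction: with phenyl in place of 2-(dimethylamino)ethenyl on that amine nitrogen, the step is a 9.3-fold lower number from compound 3 to compound 4 (0.97 log units; beyond the scatter) and is the first to touch this position. The piperazine therefore does not by itself place a compound at the weak end of the series, as the group on its far nitrogen decides much of the outcome: 4-phenylpiperazin-1-yl in place of (1,3-benzothiazol-2-yl)sulfanyl gives a 2.1-fold lower number from compound 1 to compound 4 (0.32 log units; beyond the scatter), whereas the same group in place of (5-methyl-1,3,4-thiadiazol-2-yl)sulfanyl gives a 3.2-fold higher number from compound 2 to compound 4 (0.50 log units; beyond the scatter), so it falls short of the thiadiazole compound. Nothing in the data shown explains why these numbers move as they do.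

The compounds shown leave open whether an aromatic ring on that nitrogen matters at all, or whether a plain methyl group or a benzyl group would give a similar number. They also leave open how a methoxy group or a chlorine atom on the phenyl ring would shift the number, and whether any such change could reach the thiadiazole compound.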